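Methylamino in place of methoxy on compound 2

This account rests on a few compounds, and the source may have more. Where it says the series, first, only, none or still open, it means among the compounds named here.

In a functional assay on NCI-H1993 cells (Homo sapiens) for inhibition, read by CCK-8 assay, with a stated time of 72 h (on this read-out higher numbers stand for weaker inhibition and lower numbers for stronger inhibition), compound 1 `Cc1nc2ncc(-c3cnn(C)c3)nc2n1Cc1ccc2ncccc2c1` gives > 10000 nM as its reading, which is a limit and not a number. Among the compounds with values here, compound 2 `COC(=O)c1ccc(/C=N/CNC(C)c2ccc3ncccc3c2)cc1F` stands at 1110 nM and holds the only actual number so far. Compound 3 `CNC(=O)c1ccc(/C=N/CNC(C)c2ccc3ncccc3c2)cc1F` carries methylamino in place of methoxy on a carbonyl carbon and still awaits measurement. Within the data shown here, no measured pair shows what this swap does, so only a modest shift is expected, most likely within the usual scatter. The estimated change (a 1.3-fold higher number from compound 2 to compound 3 (0.10 log units; within the scatter)) leans slightly towards weaker inhibition. For compound 3 the estimated value is 1400 nM (range 300 nM to 6500 nM).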

Compound 3, half-maximal inhibitory concentration: 191 nM
Compound 3: the middle estimate sits 7.3-fold (0.87 log units) above what was measured, and the stated range ends above it.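

In this assay, swapping methoxy for methylamino on the carbonyl carbon, which turns methoxycarbonyl into methylcarbamoyl, gives a 5.8-fold lower number from compound 2 to compound 3 (0.76 log units; beyond the scatter), a step that means stronger inhibition. Within the data shown here, this is the first measured pair to show that inhibition in these cells responds to a change at this position. The data shown give no explanation for the size or direction of this step. From the compounds shown here alone, it remains open how a plain amino group, a dimethylamino group or a longer chain on the nitrogen would read on the same carbonyl carbon, and a carboxylic acid in place of the amide is equally untested here.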